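Replacing the group on the carbonyl carbon of compound 2

This account rests on a few compounds, and the source may have more. Where it says the series, first, only, none or still open, it means among the compounds named here.

In a physicochemical assay for solubility, in simulated intestinal fluid, with a stated time of 4 h (on this read-out lower numbers stand for lower solubility and higher numbers for higher solubility), compound 1 `CCOc1nc(Nc2ccc(C(=O)NCC(C)(C)O)cc2OC)nc2[nH]ccc12` reads 25.5 ug/mL while compound 2 `CCOc1nc(Nc2ccc(C(=O)N3CC4(COC4)C3)cc2OC)nc2[nH]ccc12` reads 6.2 ug/mL and so stands lowest of the two. For the measured compounds named here, in compound 3 `CCOc1nc(Nc2ccc(C(=O)N3CCC4(CC3)CN(C)C4)cc2OC)nc2[nH]ccc12` the shared core stays and a group of 10 heavy atoms (8 carbon, 2 nitrogen; one four-membered non-aromatic ring with 1 hetero atom, one six-membered non-aromatic ring with 1 hetero atom) in place of a group of 7 heavy atoms (5 carbon, 1 nitrogen, 1 oxygen; 2 four-membered non-aromatic rings with 1 hetero atom each), on a carbonyl carbon is the only change. Going by the values given here, the one measured step that bears on this sits on the same carbonyl carbon, where a 4.1-fold lower number from compound 1 to compound 2 (0.61 log units; beyond the scatter) was seen. That single step shows that the number can move at this place, but it involves a different pair of groups and gives no firm direction. Going by a 4.1-fold lower number from compound 1 to compound 2 (0.61 log units; beyond the scatter) as the only guide to size, a step of similar magnitude is expected in this assay for the new group, tentatively upward, though no measured compound carries this group. The estimated step is a 4.8-fold higher number from compound 2 to compound 3 (0.68 log units; beyond the scatter) and remains uncertain. For compound 3 the expected solubility is 30 ug/mL within an estimated range of 6 ug/mL to 120 ug/mL on this thin evidence.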

Compound 3, solubility: 621 ug/mL
Compound 3: middle estimate off by 21-fold (1.32 log units), on the low side; the whole stated range lies below it.
By their numbers in this assay, from the lowest: compound 2; then compound 1; then compound 3.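

For the compounds shown here, at the carbonyl carbon, this assay shows a 100-fold higher number from compound 2 to compound 3 (2.00 log units; beyond the scatter), a large step where the only earlier step at this place, a 4.1-fold lower number from compound 1 to compound 2 (0.61 log units; beyond the scatter), was modest. The new group also stands clear of the open-chain group, with a 24-fold higher number from compound 1 to compound 3 (1.39 log units; beyond the scatter), and compound 3 therefore reads highest of the three, with its steps to both others beyond the scatter. The leaving and entering groups have the same computed counts of hydrogen-bond donors and acceptors and the same net charge, so these counts do not separate them, although the readings differ widely.

No measurement shown accounts for the size of this step. The change replaces the oxygen-containing pair of four-membered rings with a nitrogen-containing four-membered ring joined to a six-membered ring, all in one step, and the compounds shown leave open which part of the entering group goes with the higher number and whether a simpler group on the same carbonyl carbon, such as a piperidine, a morpholine or an open-chain dimethylamino group, would read near compound 3 or near compound 2.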